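The source may report more compounds than this note shows. Statements on the series, on what has been measured and on what is new or still open speak of the compounds shown alone.

Compound 1 `CCCCCCCSC1C2CCC(O2)C1C/C=C\CCCC(=O)O` is a thromboxane receptor antagonist of modest strength: in a functional assay on a cell-free system (plasma) for inhibition of thromboxane A2 receptor (Homo sapiens) (on this read-out lower numbers stand for stronger inhibition and higher numbers for weaker inhibition), compound 1 gives 230000 nM; 35000 nM (2 entries), with the several entries of compound 1 in this assay, 230000 nM; 35000 nM (2 entries) spread widely. Among the compounds with values here, compound 2 `O=C(O)CCC/C=C\CC1C2CCC(O2)C1CSCCCc1ccccc1` gives 5000 nM in this assay, the only number it has, beside a further entry without one. Compound 3 `CCC/C=C/CSCC1C2CCC(O2)C1C/C=C\CCCC(=O)O` differs from compound 2 only by pent-1-en-1-yl in place of phenethyl on a saturated chain carbon bound to a sulfur. Within the data shown here, no comparable step has been measured, so the expected change from compound 2 to compound 3 is a 1.8-fold higher number from compound 2 to compound 3 (0.26 log units; within the scatter), a small loss that may fall within scatter. Compound 3 is therefore expected to give 9000 nM, between 2500 nM and 35000 nM, in this assay.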

Compound 3, half-maximal inhibitory concentration: 1300 nM
Estimate against measurement, compound 3: 6.9-fold (0.84 log units) above; the whole stated range lies above it.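

Phenethyl is not required in this position: in this assay, pent-1-en-1-yl, which has no ring and fewer heavy atoms, gives a 3.8-fold lower number from compound 2 to compound 3 (0.59 log units; beyond the scatter). On a saturated chain carbon bound to a sulfur, an open chain with a double bond can therefore take the place of the aromatic ring. This step rests on single numbers, and repeat entries for one compound can differ widely: the several entries of compound 1 in this assay, 230000 nM; 35000 nM (2 entries)

The ring, the double bond and the heavy-atom count all change together here, so their contributions remain unseparated. A saturated pentyl chain or a cyclohexylethyl group in the same place would help separate them.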